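The source may hold more compounds than are shown below. What is called first, only, known or untested is meant among the compounds shown, and "the series" means these compounds.

Working notes on the series. Within the data shown here, in a functional assay on SR cells (Homo sapiens) for inhibition (a lower number here means a stronger inhibitor of growth, a higher number a weaker inhibitor of growth), compound 2 `NC(=O)c1cc(I)ccc1NC(=O)COc1ccccc1` gives 221 nM and holds the lower of the two numbers so far. Among the measured compounds shown here, compound 1 `NC(=O)c1cc(Cl)ccc1NC(=O)COc1ccccc1` gives 777 nM and is its only neighbour. Next in line is compound 3 `COc1ccc(NC(=O)COc2ccccc2)c(C(N)=O)c1`, with methoxy in place of iodo on an aromatic carbon. For the measured compounds named here, only one measured step bears on this place, and that is a 3.5-fold lower number from compound 1 to compound 2 (0.55 log units; beyond the scatter) as a modest change. Going by the values given here, no methoxy compound has a number yet, so this step is an indirect guide only. Since iodo gave the lower number in that single comparison, losing it is expected to raise the number in this assay by a similarly modest amount. The expected step is a 3.6-fold higher number from compound 2 to compound 3 (0.56 log units; beyond the scatter) as a working estimate. For compound 3 the estimated value is 800 nM (expected range 250 nM to 2500 nM).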

Compound 3, concentration for 50% growth inhibition: 392 nM
Estimate against measurement, compound 3: 2.0-fold (0.31 log units) above; the range from low to high includes it.
By their numbers in this assay, from the lowest: compounds 2, 3 and 1 (each within the scatter of the next, the first and the last beyond it).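

In this assay, methoxy in place of iodo gives a 1.8-fold higher number from compound 2 to compound 3 (0.25 log units; within the scatter), and methoxy in place of chloro gives a 2.0-fold lower number from compound 1 to compound 3 (0.30 log units; within the scatter). This carbon, para to a large group, therefore also takes a non-halogen group carrying a hydrogen-bond acceptor, with compound 3 lying within the scatter of both halogen compounds, even though those two are separated by a 3.5-fold lower number from compound 1 to compound 2 (0.55 log units; beyond the scatter). No measured property of these groups is available to account for this result.

Going by these compounds, how an amine, a carboxylic acid or a longer alkoxy chain on this carbon would read in this assay remains open. Also open, on these data alone, is whether methoxy and iodo would stay this close with a change elsewhere on the shared core.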